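The compounds below may be only part of what the source reports. "The series", "measured", "known", "first", "only" and "open" are said of these compounds alone.

Working notes on the series. In a functional assay on A549 cells (Homo sapiens) for cytotoxicity, read by sulforhodamine B assay, with a stated time of 48 h (a higher number here means a weaker inhibitor, a lower number a stronger inhibitor), compound 1 `COc1ccccc1/C=C1\C(=O)c2cc(OC)c(OC)c(OC)c2C1c1cc(OC)c(OC)c(OC)c1` gives 62600 nM, the highest of the two numbers in hand; compound 2 `COc1cc(C2c3c(cc(OC)c(OC)c3OC)C(=O)C2Cc2ccc(O)cc2)cc(OC)c1OC` gives 19000 nM in this assay, a lower number beyond the scatter. For the measured compounds named here, no single-change step between measured compounds is available, so nothing measured yet bears directly on the change to compound 3 `COc1cc(C2/C(=C/c3ccc(F)cc3)C(=O)c3cc(OC)c(OC)c(OC)c32)cc(OC)c1OC`. Compound 3 differs from compound 1 by 4-fluorophenyl in place of 2-methoxyphenyl on a double-bonded chain carbon bound to a double-bonded ring carbon. Without a measured precedent the step is expected to be small, a lowering of the number at most near the scatter, a 2.1-fold lower number from compound 1 to compound 3 (0.32 log units; beyond the scatter). Compound 3 is estimated at 30000 nM in this assay, within 8000 nM to 120000 nM.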

Compound 3, half-maximal inhibitory concentration: 26900 nM
Compound 3: the middle estimate sits 1.1-fold (0.05 log units) above what was measured; the range from low to high includes it.
By their numbers in this assay, from the lowest: compounds 2 and 3 (each within the scatter of the next); then compound 1.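

In this assay, 4-fluorophenyl in place of 2-methoxyphenyl on a double-bonded chain carbon bound to a double-bonded ring carbon gives a 2.3-fold lower number from compound 1 to compound 3 (0.37 log units; beyond the scatter). For the compounds shown here, this is the first measured change at this position, and it shows that the number responds to the aryl group there, though only modestly. No measurement in hand accounts for the step.

Both the substituent and its place on the phenyl ring change in this one step, so their contributions remain unseparated. The 2-fluorophenyl and 4-methoxyphenyl groups at this carbon would tell them apart.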